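The compounds below may be only part of what the source reports. "The series", "measured", "known", "first", "only" and "open" are said of these compounds alone.

Measured in a functional assay on MCF7 cells (Homo sapiens) for cytotoxicity, read by MTT assay, with a stated time of 24 h; a higher number here means a weaker inhibitor, a lower number a stronger inhibitor:
- compound 1 `CCN1CCN(CC(=O)Nc2ccc(-c3nc(-c4ccccc4)c(-c4ccccc4)n3C)cc2)CC1`: 80 ug/mL
- compound 2 `Cn1c(-c2ccc(NC(=O)CN3CCN(c4ccccc4)CC3)cc2)nc(-c2ccccc2)c1-c1ccccc1`: 10.7 ug/mL
- compound 3 `Cn1c(-c2ccc(NC(=O)CN3CCN(Cc4ccccc4)CC3)cc2)nc(-c2ccccc2)c1-c1ccccc1`: 80 ug/mL

Compound 1 and compound 3 stand level, together the highest of the three numbers. Compound 4 `Cn1c(-c2ccc(NC(=O)CN3CCN(Cc4ccc(Cl)cc4)CC3)cc2)nc(-c2ccccc2)c1-c1ccccc1` has chloro in place of hydrogen on an aromatic carbon, para to a large group: chloro in place of hydrogen on an aromatic carbon. Among the measured compounds shown here, no measured step tests this change directly. The measured steps swap the whole group on the amine nitrogen in a ring: a 7.5-fold higher number from compound 2 to compound 3 (0.87 log units; beyond the scatter) and a 7.5-fold lower number from compound 1 to compound 2 (0.87 log units; beyond the scatter) are modest, while no change at the digits printed from compound 1 to compound 3 (within the scatter) is within the scatter. Only a small shift is therefore expected in this assay, leaning to a lower number and not clearly beyond the scatter. The expected step is a 1.6-fold lower number from compound 3 to compound 4 (0.20 log units; within the scatter). For compound 4 the estimate is 50 ug/mL, with an expected range of 17 ug/mL to 110 ug/mL.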

Compound 4, half-maximal inhibitory concentration: 21 ug/mL
Beside the measured number, compound 4's estimate is 2.4-fold (0.38 log units) above it; measured number inside the range.
By their numbers in this assay, from the lowest: compounds 2 and 4 (each within the scatter of the next); then compounds 1 and 3 (each within the scatter of the next).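

Chloro on the benzyl ring gives a 3.8-fold lower number from compound 3 to compound 4 (0.58 log units; beyond the scatter) in this assay and so shows that this ring carbon can move the number, which the level ethyl and benzyl pair could not show. The 4-chlorobenzyl group parts from the ethyl group with a 3.8-fold lower number from compound 1 to compound 4 (0.58 log units; beyond the scatter) and stands with the phenyl group with a 2.0-fold higher number from compound 2 to compound 4 (0.29 log units; within the scatter) on this read-out. No measurement here gives a reason for the shift. From the compounds shown here alone, whether the shift is particular to chloro stays open, and fluoro, methoxy or nitrile on the same carbon would test it. Chloro on the phenyl group of compound 2 is equally open.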